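Thiosemicarbazones on a terpene scaffold: changing the aryl group

A few compounds are considered here, and "the series" means these few. Any claim that something is new, unique, unknown or untested is made for them only; others in the source may bear on it.

Compound 1, `COc1ccc(/C=N\NC(=S)NC(C)(C)CCC[C@](C)(O)[C@@H]2CC=C(C)CC2)cc1`: > 100000 nM
Compound 2, `CC1=CC[C@@H]([C@@](C)(O)CCCC(C)(C)NC(=S)N/N=C\c2ccc(N(C)C)cc2)CC1`: > 100000 nM
Compound 3, `CC1=CC[C@@H]([C@@](C)(O)CCCC(C)(C)NC(=S)N/N=C\c2cccc([N+](=O)[O-])c2)CC1`: 68600 nM

Three compounds sharing the core of compound 3 were tested in a functional assay on NCI-H460 cells (Homo sapiens) for cytotoxicity, read by sulforhodamine B assay; a higher number here means a weaker inhibitor of growth, a lower number a stronger inhibitor of growth. For compound 1 the result is a limit of the assay, > 100000 nM. For compound 2 the result is likewise a limit, > 100000 nM. Within the data shown here, compound 3 stands apart as the only compound with a number in this assay, 68600 nM, set against (the limit of > 100000 nM in this assay, at which 2 of the 3 values shown sit).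

The next compound, compound 4, `CC1=CC[C@@H]([C@@](C)(O)CCCC(C)(C)NC(=S)N/N=C\c2ccccc2Cl)CC1`, differs from compound 3 in one place: 2-chlorophenyl in place of 3-nitrophenyl on a carbon with a double bond to nitrogen. Among the measured compounds shown here, two measured steps bear on this kind of change, both ending at compound 3: an at least 1.4-fold lower number from compound 1 to compound 3 (0.16 log units; that floor lies within the scatter) and an at least 1.4-fold lower number from compound 2 to compound 3 (0.16 log units; that floor lies within the scatter). For the measured compounds named here, both floors lie within the scatter, so they show only that exchanging the aryl group moved the result from a limit to a number, by an amount that cannot be read. Going by the values given here, no measured step covers the 2-chlorophenyl group itself. The expectation is therefore a step of no size beyond the scatter, a 1.2-fold higher number from compound 3 to compound 4 (0.07 log units; within the scatter), with compound 4 estimated at 80000 nM, in a range from 30000 nM to 200000 nM, and a fair chance that this assay again reports only a limit.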

Compound 4, concentration for total growth inhibition: > 100000 nM
Compound 4: no number, only a limit; the forecaster's own chance of this, stated with the estimate: 45%; at least 1.2-fold (0.09 log units) between middle value and limit.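

In this assay, 2-chlorophenyl on the carbon with a double bond to nitrogen yields no number: compound 4 gives > 100000 nM, which is a limit of the assay. The exchange of 3-nitrophenyl for 2-chlorophenyl amounts to an at least 1.4-fold higher number from compound 3 to compound 4 (0.16 log units; that floor lies within the scatter), so it cannot be said that this change truly weakens growth inhibition, and the steps to compound 4 from compound 1 and compound 2 cannot be read, as both ends are limits. Of the four aryl groups shown, only 3-nitrophenyl gives a number, and the other results gather at a single point: the limit of > 100000 nM in this assay, at which 3 of the 4 values shown sit.

On these data alone, it remains open whether any aryl group at this place moves the result from compound 3 by more than the scatter. As far as these compounds go, how a nitrile or a carboxylic acid on the aromatic ring would read in this assay also stays unknown.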